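A Heterocycle Swap on Compound 1 and Its Expected Toxicity

The source may hold more compounds than are shown below. What is called first, only, known or untested is meant among the compounds shown, and "the series" means these compounds.

Of the compounds shown here, three have so far been measured in a functional assay on MT4 cells (Homo sapiens) for cytotoxicity; on this read-out higher numbers stand for lower toxicity in this test and lower numbers for higher toxicity in this test. Compound 1 `CNc1ncnc2c1ncn2[C@@H]1O[C@H](CO[Si](C)(C)C(C)(C)C)[C@@]2(OS(=O)(=O)C=C2N)[C@H]1O[Si](C)(C)C(C)(C)C` gives 14000 nM. Compound 3 `CC(C)(C)[Si](C)(C)OC[C@H]1O[C@@H](n2cnc3c(N)ncnc32)[C@H](O[Si](C)(C)C(C)(C)C)[C@@]12OS(=O)(=O)C=C2N` gives 7300 nM, a number that lies within the usual scatter of the value of compound 1, so the two cannot be told apart. Compound 2 `CC(C)(C)[Si](C)(C)OC[C@H]1O[C@@H](n2cnc3ncn([C@@H]4O[C@H](CO[Si](C)(C)C(C)(C)C)[C@@]5(OS(=O)(=O)C=C5N)[C@H]4O[Si](C)(C)C(C)(C)C)c3c2=O)[C@H](O[Si](C)(C)C(C)(C)C)[C@]12OS(=O)(=O)C=C2N` gives only a limit of the assay, > 150000 nM. Among the compounds with values here, that single limit, (the limit of > 150000 nM in this assay, at which 1 of the 3 values shown sits), is the only evidence beyond the two plain numbers. Of those two numbers, compound 1 holds the higher one, though its gap to compound 3 is within the scatter.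

Compound 4 `CCn1cnc2ncn([C@@H]3O[C@H](CO[Si](C)(C)C(C)(C)C)[C@@]4(OS(=O)(=O)C=C4N)[C@H]3O[Si](C)(C)C(C)(C)C)c2c1=O` differs from compound 1 in one place: a group of 12 heavy atoms (7 carbon, 4 nitrogen, 1 oxygen; one five-membered aromatic ring with 2 hetero atoms, one six-membered aromatic ring with 2 hetero atoms) in place of a group of 11 heavy atoms (6 carbon, 5 nitrogen; one five-membered aromatic ring with 2 hetero atoms, one six-membered aromatic ring with 2 hetero atoms), on a saturated ring carbon. Within the data shown here, no measured pair shows a change of this kind, so the size of the step has no precedent here. With compound 1 at 14000 nM and compound 3 at 7300 nM sitting close together, compound 4 is expected to remain in that region. The expected step is a 1.3-fold higher number from compound 1 to compound 4 (0.11 log units; within the scatter), none beyond the scatter. Compound 4 is estimated at 18000 nM, with a range from 6000 nM to 60000 nM.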

Compound 4, half-maximal cytotoxic concentration: > 150000 nM
Compound 4 was reported as a limit; the forecaster's own chance of this, stated with the estimate: 10%; middle value at least 8.3-fold (0.92 log units) from the limit.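

Swapping the group on the saturated ring carbon, next to the ring oxygen, gives an at least 10-fold higher number from compound 1 to compound 4 (1.02 log units; beyond the scatter) in this assay, the first step in this series that can be read and one that lies beyond the scatter. Compound 4 gives > 150000 nM, which is a limit of the assay and not a number. With the rest of the core of compound 1 unchanged, this shows that the heterocyclic group at this one position can by itself take the read-out to the same limit as compound 2: the limit of > 150000 nM in this assay, at which 2 of the 4 values shown sit.

The compounds shown leave open which feature of the entering group carries the step. They also leave open whether the entering group with a benzyl group or a methyl group in place of its ethyl group would sit at this limit too.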